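This account rests on a few compounds, and the source may have more. Where it says the series, first, only, none or still open, it means among the compounds named here.

Working notes on the series. Compound 1 `COc1ccc(-c2cc3c(OC)cc(OC)cc3n(C)c2=O)cc1` is the reference point. In a functional assay on J82 cells (Homo sapiens) for cytotoxicity, read by colorimetric assay and MTT assay (a higher number here means a weaker inhibitor, a lower number a stronger inhibitor), compound 1 gives 10000 nM. Compound 2 `CCOC(=O)Cn1c(=O)c(-c2ccc(OC)cc2)cc2c(OC)cc(OC)cc21` gives 10000 nM in this assay, and compound 3 `COc1ccc(-c2cc3c(OC)cc(OC)cc3n(CCCC#N)c2=O)cc1` gives 10000 nM. Compound 1 thus stands level with compounds 2 and 3 at the digits shown; the three values sit together, and no order among them can be read from them. The steps among the measured compounds, no change at the digits printed from compound 1 to compound 2 (within the scatter), no change at the digits printed from compound 1 to compound 3 (within the scatter) and no change at the digits printed from compound 2 to compound 3 (within the scatter), all alter the group on a saturated chain carbon bound to an aromatic nitrogen, and each stays within the scatter.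

Compound 4 `COc1cc(OC)c2cc(-c3ccc(O)cc3)c(=O)n(C)c2c1` is the next candidate for this assay. Relative to compound 1 the change is hydrogen in place of methyl on an oxygen on an aromatic ring. None of the measured steps touches the oxygen on the aromatic ring, so no step bears directly on this change; the only guidance is that the series has shown no movement anywhere so far. Compound 4 is therefore expected to give 10000 nM, range 4000 nM to 25000 nM, in this assay. The step of no change at the digits printed from compound 1 to compound 4 (within the scatter) is estimated to lie within the scatter.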

Compound 4, half-maximal inhibitory concentration: 10000 nM
Compound 4: middle estimate and measured number agree at the digits printed, and the stated range covers the measured number.
By their numbers in this assay, from the lowest: compounds 1, 2, 3 and 4 (each within the scatter of the next).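

Replacing methyl with hydrogen on an oxygen on an aromatic ring, which turns methoxy into hydroxy, gives no change at the digits printed from compound 1 to compound 4 (within the scatter) in this assay. Among the compounds shown here, this is the first reading at this position, and it shows that the absence of movement is not confined to the group on a saturated chain carbon bound to an aromatic nitrogen, since the 4-methoxyphenyl to 4-hydroxyphenyl change also leaves the value where it was. No measurement offered here accounts for this result.

The compounds shown leave open whether an amine or a carboxylic acid in place of the hydroxy of compound 4 would shift the value at all. Going by these compounds, it is also open whether a longer chain on that oxygen, or any change to the methoxy groups of the shared core, would do so.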